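A methyl added to the sulfonamide aryl of compound 3

The source may report more compounds than this note shows. Statements on the series, on what has been measured and on what is new or still open speak of the compounds shown alone.

In a functional assay on MCF7 cells (Homo sapiens) for antiproliferative activity, read by sulforhodamine B assay, with a stated time of 48 h (on this read-out higher numbers stand for weaker inhibition and lower numbers for stronger inhibition), three members of one series have been measured. Compound 1 `CC(=O)N(C(C)=O)C1=C(C#N)C(c2ccc(Cl)cc2)c2sc(Nc3ccc(S(N)(=O)=O)cc3)nc2O1` gives 74300 nM in this assay. Compound 2 `N#CC1=C(/N=C/c2ccc(Cl)cc2)Oc2nc(Nc3ccc(S(N)(=O)=O)cc3)sc2C1c1ccc(Cl)cc1` gives 34600 nM, and compound 3 `N#CC1=C(NS(=O)(=O)c2ccccc2)Oc2nc(Nc3ccc(S(N)(=O)=O)cc3)sc2C1c1ccc(Cl)cc1` gives 47500 nM. Compound 3 thus sits with the second highest number of the three; its nearest neighbour is compound 2, its furthest compound 1, and both of those gaps are within the scatter. Among the measured steps only the change a 2.1-fold lower number from compound 1 to compound 2 (0.33 log units; beyond the scatter) reaches beyond the scatter, while a 1.6-fold lower number from compound 1 to compound 3 (0.19 log units; within the scatter) and a 1.4-fold higher number from compound 2 to compound 3 (0.14 log units; within the scatter) do not.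

Compound 4 `Cc1ccc(S(=O)(=O)NC2=C(C#N)C(c3ccc(Cl)cc3)c3sc(Nc4ccc(S(N)(=O)=O)cc4)nc3O2)cc1` differs from compound 3 by methyl in place of hydrogen on an aromatic carbon, placed on an aromatic carbon of a six-membered aromatic ring of carbon only, para to a large group. Among the measured compounds shown here, none of the measured steps exchanges a hydrogen for a methyl on that ring, so no step bears directly on this change; the nearest precedent is the swap of the whole group on the double-bonded ring carbon, which stayed within the scatter from compound 2 to compound 3. Compound 4 is therefore expected to show a step of a 1.1-fold lower number from compound 3 to compound 4 (0.02 log units; within the scatter) that stays within the scatter. The estimate for compound 4 in this assay is 45000 nM, with a range from 20000 nM to 100000 nM.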

Compound 4, half-maximal inhibitory concentration: 71700 nM
Compound 4: the middle estimate sits 1.6-fold (0.20 log units) below what was measured; the measured number falls inside the stated range.
By their numbers in this assay, from the lowest: compounds 2, 3, 4 and 1 (each within the scatter of the next, the first and the last beyond it).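

In this assay, among the compounds shown here, the step of a 1.5-fold higher number from compound 3 to compound 4 (0.18 log units; within the scatter) is the first direct reading of methyl in place of hydrogen on this six-membered aromatic ring, para to a large group, and it shows that this change at this position cannot be told from the scatter. The same change does alter how the series compares: the step of a 2.1-fold higher number from compound 2 to compound 4 (0.32 log units; beyond the scatter) lies beyond the scatter, whereas the step from compound 2 to compound 3 stayed within it, and the step of a 1.0-fold lower number from compound 1 to compound 4 (0.02 log units; within the scatter) leaves ((4-methylphenyl)sulfonyl)amino and diacetylamino on the double-bonded ring carbon indistinguishable. Nothing available on these compounds explains these numbers.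

As far as these compounds go, what stays open is whether another group at this aromatic carbon, such as a methoxy, a chlorine atom, an amine or a carboxylic acid, would take the number beyond the scatter from compound 3. For the compounds shown here, it is also open whether methyl in place of hydrogen would read the same on an aromatic ring attached through a different link to the double-bonded ring carbon, since the only such pair here carries the sulfonylamino link.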